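Solubility notes on a short aminoalkyl side-chain series

The source may hold more compounds than are shown below. What is called first, only, known or untested is meant among the compounds shown, and "the series" means these compounds.

Measured compounds:
compound 1, `OCCCCNc1nnc(-c2ccc(F)c(F)c2Nc2ccc(I)cc2F)o1`: < 3 ug/mL
compound 2, `COCCCNc1nnc(-c2ccc(F)c(F)c2Nc2ccc(I)cc2F)o1`: < 3 ug/mL

In a physicochemical assay for solubility, read by HPLC, in phosphate buffer, at pH 6.5 (a higher number here means a more soluble compound, a lower number a less soluble compound), compound 1 gives < 3 ug/mL, and this is a limit of the assay rather than a number. Compound 2 gives < 3 ug/mL, again a limit. The step that the two limits leave unreadable from compound 1 to compound 2 therefore cannot be sized or given a direction. Among the compounds with values here, compound 1 thus stands at the lower limit of this assay, and the one other measured compound sits at the same limit (the limit of < 3 ug/mL in this assay, at which 2 of the 2 values shown sit), so nothing within the measured pair separates the two side chains.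

Compound 3, `CNCCNc1nnc(-c2ccc(F)c(F)c2Nc2ccc(I)cc2F)o1`, differs from compound 1 in methylamino in place of 2-hydroxyethyl on a saturated chain carbon, two bonds along the chain from a nitrogen on an aromatic ring. Within the data shown here, the only measured step, which runs between two limits, bears on this change without reading, and no other measured pair exists. On that basis no step beyond the scatter can be predicted for compound 3 in this assay, in either direction. The estimate for compound 3 is 4 ug/mL, with a range from 1 ug/mL to 30 ug/mL, and this number is an expectation only. The step this expectation means is an at least 1.3-fold higher number from compound 1 to compound 3 (0.12 log units; that floor lies within the scatter), expected rather than measured.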

Compound 3, solubility: 6.7 ug/mL
Estimate against measurement, compound 3: 1.7-fold (0.22 log units) below, within the range that was stated.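

Within the data shown here, this is the first readable step at this position: in this assay, methylamino in place of 2-hydroxyethyl gives an at least 2.2-fold higher number from compound 1 to compound 3 (0.34 log units; beyond the scatter), and methylamino in place of methoxymethyl gives an at least 2.2-fold higher number from compound 2 to compound 3 (0.34 log units; beyond the scatter). Both steps start from a limit, so each one fixes only a minimum size, and the true gap to compound 3 may be wider. The step between compound 1 and compound 2 still cannot be read, and the change to methylamino is the only one shown that separates a compound from the other two, which stay together: the limit of < 3 ug/mL in this assay, at which 2 of the 3 values shown sit.

The cut further out reads 4-hydroxybutyl to 2-(methylamino)ethyl, so the chain and the atom it carries change together, and the compounds shown cannot assign the step to either one alone. A longer chain carrying methylamino, or a shorter chain carrying hydroxyl, would pull the two apart, and a dimethylamino group or a carboxylic acid in the same place would show whether the step is particular to methylamino.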